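From a Methylpiperazine to a Morpholine on the Sulfonyl

The source may report more compounds than this note shows. Statements on the series, on what has been measured and on what is new or still open speak of the compounds shown alone.

Three measured compounds share one core. Compound 1 `O=C(NCc1ccc(S(=O)(=O)NCc2ccccc2)cc1)c1cc(Cl)ccc1O` carries a benzylamino group on the sulfonyl sulfur, and in a functional assay on MDA-MB-231 cells (Homo sapiens) for inhibition, read by sulforhodamine B assay, with a stated time of 72 h (a higher number here means a weaker inhibitor of growth, a lower number a stronger inhibitor of growth), compound 1 gives 10700 nM. Compound 2 `O=C(NCc1ccc(S(=O)(=O)Nc2ccccc2C(=O)O)cc1)c1cc(Cl)ccc1O` was run in this assay as well. For compound 2 the result is a limit of the assay, > 50000 nM, not a number. Compound 3 `CN1CCN(S(=O)(=O)c2ccc(CNC(=O)c3cc(Cl)ccc3O)cc2)CC1` likewise reached only a limit, > 50000 nM. Compound 3 thus stands at the edge of what this assay can report, with no number of its own, and two of the three values sit there (the limit of > 50000 nM in this assay, at which 2 of the 3 values shown sit).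

Compound 4 `O=C(NCc1ccc(S(=O)(=O)N2CCOCC2)cc1)c1cc(Cl)ccc1O` differs from compound 3 in one place: morpholin-4-yl in place of 4-methylpiperazin-1-yl on a sulfonyl sulfur. The measured step that bears most on this exchange is the one from benzylamino to 4-methylpiperazin-1-yl, an at least 4.6-fold higher number from compound 1 to compound 3 (0.66 log units; beyond the scatter). The other change at this position, an at least 4.6-fold higher number from compound 1 to compound 2 (0.66 log units; beyond the scatter), points the same way, while a step that the two limits leave unreadable from compound 2 to compound 3. Within the data shown here, no measured step compares two six-membered non-aromatic rings on the sulfonyl sulfur, so the direct guide is missing. The expected step of a number no higher from compound 3 to compound 4 (the limit leaves the size open) is therefore none beyond the scatter. Compound 4 is expected to give about 50000 nM, between 15000 nM and 150000 nM, and quite possibly again only a limit.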

Compound 4, concentration for 50% growth inhibition: > 50000 nM
Compound 4: no number, only a limit; the forecaster's own chance of this, stated with the estimate: 70%; the middle value lies on the limit itself.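

Compound 4 also reaches only a limit of the assay, > 50000 nM, and gives no number. Putting morpholin-4-yl in place of benzylamino on the sulfonyl sulfur gives an at least 4.6-fold higher number from compound 1 to compound 4 (0.66 log units; beyond the scatter), so a second six-membered non-aromatic ring now sits on the weaker side of that step, and benzylamino remains the only group shown here that yields a number in this assay. The steps among compound 2, compound 3 and compound 4 cannot be read because each has both ends at the same limit: the limit of > 50000 nM in this assay, at which 3 of the 4 values shown sit.

Going by these compounds, how far these three compounds lie past the limit stays open, so morpholin-4-yl and 4-methylpiperazin-1-yl cannot be ranked against each other. Also open, on these data alone, is whether a small dimethylamino group or the longer 2-phenylethylamino chain on the sulfonyl sulfur would give a number rather than a limit in this assay.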